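Cinnamate ester series: one methoxy group removed

The compounds below may be only part of what the source reports. "The series", "measured", "known", "first", "only" and "open" are said of these compounds alone.

The shared core is that of compound 1 `COc1cc(OC)c(OC)cc1/C=C/COC(=O)/C=C/c1ccc(OC)c(OC)c1`. In a functional assay on the whole organism (strain Kunming) with Mus musculus as the target, with a stated time of 0.5 h, at a dose of 100 mg/kg by the intraperitoneal route (a higher number here means a weaker effect of the compound at the dose given, a lower number a stronger effect), compound 1 gives 100%, level with compound 2 `COc1cc(OC)c(OC)cc1/C=C/COC(=O)/C=C/c1ccccc1C(F)(F)F` at 100% and with compound 3 `COc1cc(OC)c(OC)cc1/C=C/COC(=O)/C=C/c1ccc(F)cc1` at 100%. Compound 4 `COc1ccc(/C=C/C(=O)OC/C=C/c2cc(OC)c(OC)cc2OC)cc1` differs from compound 1 by hydrogen in place of methoxy on an aromatic carbon. Among the measured compounds shown here, the steps that bear on this are the ones that exchange the 3,4-dimethoxyphenyl group: no change at the digits printed from compound 1 to compound 2 (within the scatter) and no change at the digits printed from compound 1 to compound 3 (within the scatter), and between those replacements no change at the digits printed from compound 2 to compound 3 (within the scatter); none moved beyond the scatter. Loss of a single methoxy group is therefore expected to leave this assay unchanged, the expected step being no change at the digits printed from compound 1 to compound 4 (within the scatter). Compound 4 is estimated at 100%, within 85% to 100%.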

Compound 4, a percentage reported as activity, at one dose (the size of the read-out at that dose, not a potency): 100%
Beside the measured number, compound 4's estimate shows no gap at the digits printed; the measured number falls inside the stated range.
By their numbers in this assay, from the lowest: compounds 1, 2, 3 and 4 (each within the scatter of the next).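

In this assay the removal of one methoxy group, read as 3,4-dimethoxyphenyl to 4-methoxyphenyl, gives no change at the digits printed from compound 1 to compound 4 (within the scatter); unlike the earlier exchanges of the whole aryl group, this isolates the methoxy ortho to a methoxy group, and its loss leaves the read-out level. The 4-methoxyphenyl group also stands level with the other replacements, with no change at the digits printed from compound 3 to compound 4 (within the scatter) for methoxy in place of fluoro and no change at the digits printed from compound 2 to compound 4 (within the scatter) against 2-(trifluoromethyl)phenyl. No available data give a reason for this flat picture. On these data alone, whether an amine or a carboxylic acid on this aromatic ring would move the read-out stays open.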